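Moving the Pyridine Nitrogen: What to Expect for Compound 4

The source may report more compounds than this note shows. Statements on the series, on what has been measured and on what is new or still open speak of the compounds shown alone.

Compound 1, `Cn1cc(C(=O)Nc2ccc(-c3ccccc3)c(C(F)(F)F)c2)c(=O)c2cnccc21`, gives 4.9 ug/mL in a physicochemical assay for solubility, in simulated intestinal fluid, at pH 7.4; a lower number here means a less soluble compound, a higher number a more soluble compound.
Compound 2, `Cn1cc(C(=O)Nc2ccc(-c3ccccn3)c(C(F)(F)F)c2)c(=O)c2ccccc21`, gives 5.2 ug/mL in this assay.
Compound 3, `COc1ccncc1C(=O)NC(=O)Nc1ccc(-c2ccccc2)c(C(F)(F)F)c1`, gives 16 ug/mL in this assay.

Compound 2 holds the second highest of these three numbers. Its value and that of compound 1 lie within the usual scatter of each other, so no order between them can be claimed, while compound 3 stands clearly higher, beyond the scatter. Compound 4, `Cn1cc(C(=O)Nc2ccc(-c3ccncc3)c(C(F)(F)F)c2)c(=O)c2ccccc21`, differs from compound 2 in one place: pyridin-4-yl in place of pyridin-2-yl on an aromatic carbon. Among the compounds with values here, no pair of measured compounds shows this change, so the expected step rests on the structural change alone. A modest rise is expected, a 1.5-fold higher number from compound 2 to compound 4 (0.19 log units; within the scatter), which may still fall inside the scatter. Compound 4 is estimated at 8 ug/mL, within a range of 3 ug/mL to 20 ug/mL.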

Compound 4, solubility: 12 ug/mL
Compound 4: middle estimate off by 1.5-fold (0.18 log units), on the low side, and the stated range covers the measured number.
By their numbers in this assay, from the lowest: compounds 1 and 2 (each within the scatter of the next); then compounds 4 and 3 (each within the scatter of the next).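

Swapping pyridin-2-yl for pyridin-4-yl keeps the same atoms and moves only the ring nitrogen, yet it gives a 2.3-fold higher number from compound 2 to compound 4 (0.36 log units; beyond the scatter) in this assay. Within the data shown here, this is the first clean comparison at this position, ortho to a trifluoromethyl group, and it shows that the number can respond to the placement of that nitrogen alone. Nothing available explains why the step occurs.

Still open, on these data alone, is where pyridin-3-yl would fall. It is also unclear whether the same swap would give a similar step on the other cores shown.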